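The source may report more compounds than this note shows. Statements on the series, on what has been measured and on what is new or still open speak of the compounds shown alone.

Of the compounds shown here, three have so far been measured in an ADME assay on L6 cells (Rattus norvegicus) for cytotoxicity, with a stated time of 72 h (a higher number here means a weaker inhibitor, a lower number a stronger inhibitor), and a fourth is waiting. Compound 2 `CCN(CC)CC(=O)OC1CC2(N3CCCCC3)CC(c3ccccc3)C1C(c1ccccc1)C2` gives 23900 nM in this assay. Compound 1 `CCN(CC)CC(=O)OC1CC2(N(C)C)CC(c3ccccc3)C1C(c1ccccc1)C2` differs from it by dimethylamino in place of piperidin-1-yl on a saturated ring carbon; in this assay compound 1 gives 30100 nM, and the step is a 1.3-fold higher number from compound 2 to compound 1 (0.10 log units; within the scatter). Compound 3 `O=C(CN1CCCCC1)OC1CC2(N3CCCCC3)CC(c3ccccc3)C1C(c1ccccc1)C2` differs from compound 2 in another way, (piperidin-1-yl in place of diethylamino on a saturated chain carbon bound to a carbonyl carbon); in this assay compound 3 gives 60400 nM, and the step is a 2.5-fold higher number from compound 2 to compound 3 (0.40 log units; beyond the scatter). Compound 3 thus carries the highest of the three numbers, but its gap to compound 1 lies within the scatter, so only its gap to compound 2 counts as a real difference.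

Compound 4 `CN(C)C12CC(OC(=O)CN3CCCCC3)C(C(c3ccccc3)C1)C(c1ccccc1)C2` has not yet been measured. It differs from compound 3 by dimethylamino in place of piperidin-1-yl on a saturated ring carbon. Among the compounds with values here, this is the same kind of change as the one from compound 2 to compound 1, but made on a different core: around the place, the ring atom bears a (((piperidin-1-yl)methyl)carbonyl)oxy group in compound 3, where in compound 2 it bears a (((diethylamino)methyl)carbonyl)oxy group (9 heavy atoms). Within the data shown here, the one earlier example of this change stayed within the scatter. Because of a 1.3-fold higher number from compound 2 to compound 1 (0.10 log units; within the scatter) a step of similar size is expected here, a 1.2-fold higher number from compound 3 to compound 4 (0.06 log units; within the scatter). Compound 4 is therefore estimated at 70000 nM, with a likely range from 35000 nM to 140000 nM. That expectation rests on a single earlier step and on two cores that differ only modestly, so it is held loosely until the number arrives.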

Compound 4, half-maximal inhibitory concentration: 29300 nM
The estimate for compound 4 lay 2.4-fold (0.38 log units) above the measured number; the whole stated range lies above it.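

In this assay, dimethylamino in place of piperidin-1-yl on the saturated ring carbon gives a 2.1-fold lower number from compound 3 to compound 4 (0.31 log units; beyond the scatter), while piperidin-1-yl in place of diethylamino on the chain carbon bound to the carbonyl carbon gives a 1.0-fold lower number from compound 1 to compound 4 (0.01 log units; within the scatter). The ring-carbon change thus stayed within the scatter on one core and passed just beyond it on the other, but this contrast is not firm: the data show neither that the core alters the effect of this change nor that the effect carries over exactly, and with only two examples the gap between them is no larger than two such steps can produce by scatter alone: the same change on two cores in this assay, a 1.3-fold higher number (0.10 log units; within the scatter) from compound 2 to compound 1 and a 2.1-fold lower number (0.31 log units; beyond the scatter) from compound 3 to compound 4, 2.6-fold (0.41 log units) apart, within the scatter of two such steps The chain change reads the same way, beyond the scatter on one core and within it on the other, with no demonstrated difference between the two steps: the same change on two cores in this assay, a 2.5-fold higher number (0.40 log units; beyond the scatter) from compound 2 to compound 3 and a 1.0-fold lower number (0.01 log units; within the scatter) from compound 1 to compound 4, 2.6-fold (0.41 log units) apart, within the scatter of two such steps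

The compounds shown leave open whether a different cyclic amine, such as morpholin-4-yl or pyrrolidin-1-yl, would give similarly small steps at either place. They also leave open whether an amide in place of the ester link would shift the numbers in this series.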